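This account rests on a few compounds, and the source may have more. Where it says the series, first, only, none or still open, it means among the compounds named here.

Three related compounds have been measured in a functional assay on MCF7 cells (Homo sapiens) for antiproliferative activity, read by MTT assay, with a stated time of 48 h; a lower number here means a stronger inhibitor, a higher number a weaker inhibitor. Compound 1 `Cc1ccc2[nH]c3c(c2c1)CC[C@]1(C3=O)[C@@H](c2ccccc2)[C@@H](c2ccccc2)N[C@@]12C(=O)Nc1ccccc12` gives 19000 nM in this assay. Compound 2 `O=C1Nc2ccccc2[C@]12N[C@H](c1ccccc1)[C@H](c1cccs1)[C@@]21CCc2c([nH]c3ccc(Cl)cc23)C1=O` gives 13000 nM. Compound 3 `O=C1Nc2ccccc2[C@]12N[C@H](c1ccccc1)[C@H](c1cccs1)[C@@]21CCc2c([nH]c3ccccc23)C1=O` gives 15000 nM. On these numbers compound 3 sits alongside the other two: its number and that of compound 2 lie within the usual scatter of each other, and so do its number and that of compound 1, so nothing separates the three beyond ordinary measurement noise.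

The step now considered leads from compound 3 to compound 4 `COc1ccc([C@H]2[C@@H](c3ccccc3)N[C@@]3(C(=O)Nc4ccccc43)[C@]23CCc2c([nH]c4ccccc24)C3=O)cc1`, in which (4-methoxyphenyl in place of thiophen-2-yl on a saturated ring carbon). For the measured compounds named here, only one measured step is available, and it concerns a different position: a 1.2-fold higher number from compound 2 to compound 3 (0.06 log units; within the scatter). That step does not touch the group that changes here. Compound 1, which carries a phenyl group at the same saturated ring carbon, differs from compound 3 in a second place as well, so its number can only be noted, and it too lies within the scatter of compound 3.

Going by the values given here, with no measured step matching this change and all three numbers lying together, the expectation for this assay is no change beyond the scatter, and the step from compound 3 to compound 4 is estimated as no change at the digits printed from compound 3 to compound 4 (within the scatter). Compound 4 is therefore expected to give about 15000 nM, within a range from 6000 nM to 40000 nM.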

Compound 4, half-maximal inhibitory concentration: 17000 nM
For compound 4 the middle estimate is 1.1-fold (0.05 log units) below the measured one; the range from low to high includes it.
By their numbers in this assay, from the lowest: compounds 2, 3, 4 and 1 (each within the scatter of the next).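

For the compounds shown here, replacing thiophen-2-yl with 4-methoxyphenyl on this saturated ring carbon gives the first direct reading of this position in this assay and amounts to a 1.1-fold higher number from compound 3 to compound 4 (0.05 log units; within the scatter) in this single pair. Going by these compounds alone, the earlier compounds could only hint at this position, since the one earlier step concerned a chloro group elsewhere on the core and compound 1 differs from compound 3 in two places. Here, a five-membered aromatic ring containing sulfur gives way to a larger six-membered carbon ring carrying a methoxy group, and the assay cannot distinguish the two compounds; no supporting measurement is available to interpret this result.

The compounds shown leave open whether anything placed on this carbon can move the number beyond the scatter, for instance an amine, a carboxylic acid or a longer chain in place of the aromatic ring. Within the data shown here, they also contain no single-place pair that isolates the methoxy group, so its contribution, if any, remains unknown.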